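Replacing the Aryl Ether of Compound 3 by a Nitrile

The compounds below may be only part of what the source reports. "The series", "measured", "known", "first", "only" and "open" are said of these compounds alone.

Of the compounds shown here, three sharing one core have been measured in a functional assay for inhibition of sodium/hydrogen exchanger (Oryctolagus cuniculus); on this read-out higher numbers stand for weaker inhibition and lower numbers for stronger inhibition. Compound 1 `CCCc1cc(C)c(C(=O)N=C(N)N)cc1S(C)(=O)=O` gives 5.7 nM. Compound 2 `Cc1cc(Sc2ccc(Cl)cc2)c(S(C)(=O)=O)cc1C(=O)N=C(N)N` gives 19 nM, and compound 3 `Cc1cc(Oc2ccc(Cl)cc2)c(S(C)(=O)=O)cc1C(=O)N=C(N)N` gives 13 nM. Compound 3 stands second highest of these three numbers: the step of a 1.5-fold lower number from compound 2 to compound 3 (0.16 log units; within the scatter) lies within the scatter, whereas the step of a 2.3-fold higher number from compound 1 to compound 3 (0.36 log units; beyond the scatter) and the step of a 3.3-fold higher number from compound 1 to compound 2 (0.52 log units; beyond the scatter) both lie beyond it.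

Compound 4 `Cc1cc(C#N)c(S(C)(=O)=O)cc1C(=O)N=C(N)N` has not yet been measured. It differs from compound 3 by cyano in place of 4-chlorophenoxy on an aromatic carbon. Among the compounds with values here, no measured step involves a cyano group, so the change from compound 3 to compound 4 has no direct precedent among the three. Within the data shown here, the only bearing evidence is that compound 1, with propyl in that place, gives the lowest of the three numbers, the step being a 2.3-fold higher number from compound 1 to compound 3 (0.36 log units; beyond the scatter), while the two substituted phenyl groups of compound 2 and compound 3 give numbers within the scatter of each other, a 1.5-fold lower number from compound 2 to compound 3 (0.16 log units; within the scatter). On that basis a modest lowering of the number, or none beyond the scatter, is expected, a 1.6-fold lower number from compound 3 to compound 4 (0.21 log units; within the scatter). The estimate for compound 4 in this assay is 8 nM, with a range from 3 nM to 25 nM.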

Compound 4, half-maximal inhibitory concentration: 70 nM
The estimate for compound 4 lay 8.8-fold (0.94 log units) below the measured number; measured number above the stated range.
By their numbers in this assay, from the lowest: compound 1; then compounds 3 and 2 (each within the scatter of the next); then compound 4.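

In this assay, the place ortho to a methylsulfonyl group proves more sensitive to its substituent than the first three compounds showed: cyano gives a step beyond the scatter against each aryl group, namely a 5.4-fold higher number from compound 3 to compound 4 (0.73 log units; beyond the scatter) and a 3.7-fold higher number from compound 2 to compound 4 (0.57 log units; beyond the scatter). Removing the aromatic ring does not by itself decide the outcome, since propyl and cyano both lack a ring yet lie furthest apart of any pair here, with a large step (a 12-fold higher number from compound 1 to compound 4 (1.09 log units; beyond the scatter)), while the two ring-bearing groups fall between them; the heavy-atom drop from 8 to 2 on going from 4-chlorophenoxy to cyano thus brings no lower number. Nothing available here accounts for this rise.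

The compounds shown leave open where an amine, a methoxy group or a chain longer than propyl would fall in this order, and so whether propyl's low number is particular to that group or shared by other saturated chains. They also leave open whether a carboxamide or an ethynyl group in this place would track cyano or propyl.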